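Hydroxyl for chlorine on the aryl hydrazone of compound 3

The source may hold more compounds than are shown below. What is called first, only, known or untested is meant among the compounds shown, and "the series" means these compounds.

Compound 3 `CC1CCC(=NNc2c(Cl)cccc2Cl)c2ncc(C(=O)O)c(=O)n21` bears a 2,6-dichlorophenyl group on the hydrazone nitrogen of the shared core. In a functional assay on the whole organism with Rattus norvegicus as the target (on this read-out higher numbers stand for an effect only at larger amounts of compound and lower numbers for an effect already at smaller amounts), compound 3 gives only a limit, > 100 umol/kg. Compound 2 `CC1CCC(=NNc2ccc(Cl)cc2Cl)c2ncc(C(=O)O)c(=O)n21` also gives only a limit in this assay, > 100 umol/kg. The unsubstituted parent, compound 1 `CC1CCC(=NNc2ccccc2)c2ncc(C(=O)O)c(=O)n21`, gives 1.2 umol/kg in this assay. Both chlorinated analogues thus stand far from compound 1, with an at least 83-fold higher number from compound 1 to compound 2 (1.92 log units; beyond the scatter) and an at least 83-fold higher number from compound 1 to compound 3 (1.92 log units; beyond the scatter), both resting on (the limit of > 100 umol/kg in this assay, at which 2 of the 3 values shown sit). Between the two dichlorinated compounds the step is a step that the two limits leave unreadable from compound 2 to compound 3.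

Compound 4 `CC1CCC(=NNc2cc(Cl)ccc2O)c2ncc(C(=O)O)c(=O)n21` is the next change: 5-chloro-2-hydroxyphenyl in place of 2,6-dichlorophenyl on an amine nitrogen. Within the data shown here, the two measured steps that bear on it, from compound 1 to compound 2 and from compound 1 to compound 3, were both large rises in the number when chlorine entered the phenyl ring; no measured pair shows a hydroxyl, and compound 3 itself stands only at a limit, so the step cannot be read from the numbers. With one chlorine removed and a hydroxyl entering, the expectation is a step of an at least 3.3-fold lower number from compound 3 to compound 4 (0.52 log units; beyond the scatter) back toward lower numbers. Compound 4 is estimated at 30 umol/kg, within 5 umol/kg to 150 umol/kg.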

Compound 4, dose for 50% inhibition: > 100 umol/kg
Compound 4: no number, only a limit; the forecaster's own chance of this, stated with the estimate: 35%; at least 3.3-fold (0.52 log units) between middle value and limit.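

In this assay compound 4 also gives only a limit, > 100 umol/kg. Compound 4 stands as far from the unsubstituted parent as the two dichlorinated analogues, with an at least 83-fold higher number from compound 1 to compound 4 (1.92 log units; beyond the scatter), so on this amine nitrogen a hydroxyl and one chlorine on the phenyl ring give no return toward compound 1, and the loss is not confined to rings with two chlorines. The steps among compound 2, compound 3 and compound 4 cannot be read, so no order among these three can be given: the limit of > 100 umol/kg in this assay, at which 3 of the 4 values shown sit.

Going by these compounds, what actual numbers lie behind the three limits stays open. On these data alone, it is also open whether a phenyl ring carrying only a hydroxyl, a single chlorine, a methyl or a methoxy group would stay close to compound 1 or reach the same limit.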